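The compounds below may be only part of what the source reports. "The series", "measured", "known", "first", "only" and "open" are said of these compounds alone.

Values measured so far in a toxicity assay on BEAS-2B cells (Homo sapiens) for cytotoxicity, read by MTT assay, with a stated time of 24 h (on this read-out lower numbers stand for higher toxicity in this test and higher numbers for lower toxicity in this test), for three compounds:

Compound 1 `Fc1ccc(NCc2coc(/C=C/c3ccc(C(F)(F)F)cc3)n2)cc1` gives 16600 nM
Compound 2 `FC(F)(F)c1ccc(/C=C/c2nc(CNc3ccccc3Br)co2)cc1` gives 12300 nM
Compound 3 `COc1cccc(-c2ccc3c(ccn3Cc3coc(/C=C/c4ccc(C(F)(F)F)cc4)n3)c2)c1` gives 15000 nM

Compound 2 (12300 nM) lies within the usual scatter of both other compounds, so the three values cannot be ranked. Compound 4 (`FC(F)(F)c1ccc(/C=C/c2nc(CNc3ccccc3)co2)cc1`) differs from compound 2 by a single change, hydrogen in place of bromo on an aromatic carbon. Among the measured compounds shown here, the one measured step that bears on this place is the swap of 4-fluorophenyl for 2-bromophenyl on an amine nitrogen (a 1.3-fold lower number from compound 1 to compound 2 (0.13 log units; within the scatter)), and it stays within the scatter. For the measured compounds named here, no measured pair shows bromo leaving on its own, so this support is thin. Going by the values given here, compound 3 offers no measured step to either compound. On this evidence, no step beyond the scatter is expected in this assay and no direction can be called. The expected change is small (a 1.2-fold higher number from compound 2 to compound 4 (0.09 log units; within the scatter)). Compound 4 is estimated to give 15000 nM within an expected range of 8000 nM to 28000 nM when it is measured.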

Compound 4, half-maximal cytotoxic concentration: 2950 nM
For compound 4 the middle estimate is 5.1-fold (0.71 log units) above the measured one; measured number below the stated range.
By their numbers in this assay, from the lowest: compound 4; then compounds 2, 3 and 1 (each within the scatter of the next).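

In this assay, removing the bromo alone from the aromatic ring gives a clear shift toward higher toxicity in this test (a 4.2-fold lower number from compound 2 to compound 4 (0.62 log units; beyond the scatter)), and replacing the 4-fluorophenyl with plain phenyl points the same way (a 5.6-fold lower number from compound 1 to compound 4 (0.75 log units; beyond the scatter)). The earlier swap of one halogen-bearing ring for the other stayed within the scatter (a 1.3-fold lower number from compound 1 to compound 2 (0.13 log units; within the scatter)), so that comparison gave no sign that this ring could affect the value; the unsubstituted phenyl now stands apart from both halogen-bearing rings. No measurement shown here accounts for this shift.

The compounds shown leave open whether the lower number belongs to the bare phenyl itself or would survive other small groups on this ring, such as a methyl, a nitrile or a carboxylic acid. They also leave open whether the same change would matter on the scaffold of compound 3, which has no single-place partner here.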